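The compounds below may be only part of what the source reports. "The series", "measured", "known", "first", "only" and "open" are said of these compounds alone.

For the measured compounds named here, in an ADME assay on Huh-5-2 cells (Homo sapiens) for cytotoxicity, read by WST assay, with a stated time of 3 days (on this read-out lower numbers stand for higher toxicity in this test and higher numbers for lower toxicity in this test), compound 2 `O=c1c(OCc2ccc(Br)cc2)c(-c2ccccc2)oc2cc(O)cc(O)c12` gives 2000 nM, the lowest of the two numbers measured so far; compound 1 `O=c1c(OCc2ccccc2[N+](=O)[O-])c(-c2ccccc2)oc2cc(O)cc(O)c12` gives 51000 nM in this assay. Going by the values given here, the one measured step, a 26-fold lower number from compound 1 to compound 2 (1.41 log units; beyond the scatter), exchanges a whole substituted ring and so bears only loosely on the next change. Compound 3 `Cc1ccc(COc2c(-c3ccccc3)oc3cc(O)cc(O)c3c2=O)cc1` differs from compound 2 by methyl in place of bromo on an aromatic carbon. Among the compounds with values here, no measured step isolates this change, so only a small step in this assay is expected, namely a 1.5-fold higher number from compound 2 to compound 3 (0.18 log units; within the scatter). Compound 3 is therefore estimated at 3000 nM, within a range from 1000 nM to 10000 nM.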

Compound 3, half-maximal cytotoxic concentration: 40000 nM
Compound 3: the middle estimate sits 13-fold (1.12 log units) below what was measured; measured number outside the range, above it.
By their numbers in this assay, from the lowest: compound 2; then compounds 3 and 1 (each within the scatter of the next).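

On the aromatic carbon para to a large group, a change of one heavy atom matters a great deal in this assay: methyl in place of bromo gives a 20-fold higher number from compound 2 to compound 3 (1.30 log units; beyond the scatter). The step of a 1.3-fold lower number from compound 1 to compound 3 (0.11 log units; within the scatter) lies within the scatter, so the low number of compound 2 goes with the bromo rather than with any substituted ring. No measured evidence here explains this. Going by these compounds, whether chloro or methoxy on this carbon behaves like bromo or like methyl stays open, as does whether bromo keeps this effect on another ring carbon.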